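Removing the benzyl group from the imidazole nitrogen

The source may report more compounds than this note shows. Statements on the series, on what has been measured and on what is new or still open speak of the compounds shown alone.

Compound 3 `CCCCCCCC/N=c1\nc(N)c2ncn(Cc3ccc(F)cc3)c2c(N)n1` gives 3800 nM in a functional assay on PC-3 cells (Homo sapiens) for antiproliferative activity, read by WST assay, with a stated time of 72 h; a lower number here means a stronger inhibitor, a higher number a weaker inhibitor. Among the three measured compounds it has the lowest number, but compound 1 `CCCCCCCCCCCCCCCCCC/N=c1\nc(N)c2ncn(Cc3ccccc3)c2c(N)n1` with 5450 nM and compound 2 `CCCCCCCC/N=c1\nc(N)c2ncn(Cc3ccc(OC)cc3)c2c(N)n1` with 5900 nM both lie within the scatter of it, so no order can be drawn. Within the data shown here, the only single-point step measured, a 1.6-fold lower number from compound 2 to compound 3 (0.19 log units; within the scatter), exchanges one substituent on the benzyl ring for another. Among the measured compounds shown here, compound 4 `CCCCCCCC/N=c1\nc(N)c2nc[nH]c2c(N)n1` differs from compound 3 by hydrogen in place of 4-fluorobenzyl on an aromatic nitrogen, so the whole benzyl group is lost rather than altered; no measured step bears on such a removal. Compound 4 is therefore estimated with a modest weakening, a 2.1-fold higher number from compound 3 to compound 4 (0.32 log units; beyond the scatter), at 8000 nM in this assay, within 3000 nM to 25000 nM.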

Compound 4, half-maximal inhibitory concentration: "not active" (no number reported)
No number was reported for compound 4; no gap can be computed for the estimate.
By their numbers in this assay, from the lowest: compounds 3, 1 and 2 (each within the scatter of the next).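

Among these compounds, compound 4 is reported as "not active" in this assay, without a number, so no step from compound 3 to compound 4 can be read. The compounds shown leave open how other groups on that aromatic nitrogen would compare with 4-fluorobenzyl. No measurement shown offers an explanation for this result.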